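A few compounds are considered here, and "the series" means these few. Any claim that something is new, unique, unknown or untested is made for them only; others in the source may bear on it.

Of the compounds shown here, two built on a shared core have been tested in an assay for inhibition of prostacyclin synthase (Homo sapiens), using microsomes; a higher number here means a weaker inhibitor, a lower number a stronger inhibitor. Among the compounds with values here, compound 1 `N#Cc1ccc(C2OCC(C/C=C\CCC(=O)O)C(c3cccnc3)O2)cc1` is the first. In this assay compound 1 gives > 100000 nM, which is a limit of the assay and not a number. Compound 2 `Cc1ccc(C#N)c(OC(C)(C)C2OCC(C/C=C\CCC(=O)O)C(c3cccnc3)O2)c1` is the second. In this assay compound 2 gives > 100000 nM, again a limit and not a number. Within the data shown here, compound 2 therefore stands only at a limit, and the one further value shown sits at the same limit (the limit of > 100000 nM in this assay, at which 2 of the 2 values shown sit). Among the measured compounds shown here, the two measured compounds differ in more than one place, so no step between them can be stated; their two values show only that neither reaches a measurable number.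

Compound 3 `CSc1ccccc1OC(C)(C)C1OCC(C/C=C\CCC(=O)O)C(c2cccnc2)O1` is not yet measured. It differs from compound 2 in this way: 2-(methylsulfanyl)phenyl in place of 2-cyano-5-methylphenyl on an oxygen on a saturated carbon. For the measured compounds named here, no measured step covers such a change, and two limits give no direction to lean on. The step is therefore expected to be none beyond the scatter, a number no higher from compound 2 to compound 3 (the limit leaves the size open). Compound 3 is expected at 100000 nM, in a range from 30000 nM to 300000 nM, most likely reported again as a limit.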

Compound 3, half-maximal inhibitory concentration: > 100000 nM
Compound 3: a limit, no number; the forecaster's own chance of this, stated with the estimate: 75%; the middle value sits exactly at the limit.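

No step from compound 2 to compound 3 can be read, and compound 3, like compound 2, gives only a limit and not a number: the limit of > 100000 nM in this assay, at which 3 of the 3 values shown sit.

The compounds shown leave open how strongly any of the three inhibits in this assay, and whether any change on the shared core would give a measurable number.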